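Shortening a hydroxyalkyl chain on a triazolopyrimidine binder

A few compounds are considered here, and "the series" means these few. Any claim that something is new, unique, unknown or untested is made for them only; others in the source may bear on it.

Measured so far in an assay on isolated protein for binding affinity to adenosine receptor A1 (Bos taurus); on this read-out higher numbers stand for weaker inhibition and lower numbers for stronger inhibition:
- compound 1, `OCCNc1nc(-c2ccccc2)nc2c1nnn2Cc1ccccc1`: 38000000 nM
- compound 2, `COc1ccc(C(=O)Nc2nc(-c3ccccc3)nc3c2nnn3Cc2ccccc2F)cc1`: 21900000 nM
- compound 3, `OCCCNc1nc(-c2ccccc2)nc2c1nnn2Cc1ccccc1F`: 3700000 nM

Going by the values given here, compound 3 gives the lowest number of the three; its nearest neighbour is compound 2, and the single one-place step recorded, a 5.9-fold lower number from compound 2 to compound 3 (0.77 log units; beyond the scatter), separates them. Compound 1 sits furthest away with a higher number still.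

Compound 4, `OCCNc1nc(-c2ccccc2)nc2c1nnn2Cc1ccccc1F`, keeps the core and the fluorinated benzyl group of compound 3 but carries hydroxy in place of hydroxymethyl on a saturated chain carbon, two bonds along the chain from a nitrogen on an aromatic ring. Among the compounds with values here, no measured step covers this exact change, so it cannot be read off directly. What can be said is that compound 1 also carries a 2-hydroxyethyl group, though with an unfluorinated benzyl group, and its value in this assay is plainly higher than that of compound 3. Compound 4 shares one feature with each of them, so a number between the two, somewhat higher than compound 3, is expected: the estimated step is a 2.7-fold higher number from compound 3 to compound 4 (0.43 log units; beyond the scatter), modest but probably beyond the scatter. For compound 4 the estimate in this assay is 10000000 nM, with a range from 2500000 nM to 40000000 nM.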

Compound 4, inhibition constant: 54000000 nM
For compound 4 the middle estimate is 5.4-fold (0.73 log units) below the measured one; measured number above the stated range.
By their numbers in this assay, from the lowest: compound 3; then compounds 2, 1 and 4 (each within the scatter of the next, the first and the last beyond it).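

On this nitrogen chain, one carbon matters a great deal: cutting 3-hydroxypropyl down to 2-hydroxyethyl gives a 15-fold higher number from compound 3 to compound 4 (1.16 log units; beyond the scatter) in this assay, a large step. The order of the groups on that nitrogen also changes, since 2-hydroxyethyl in place of the (4-methoxyphenyl)carbonyl group gives a 2.5-fold higher number from compound 2 to compound 4 (0.39 log units; beyond the scatter), whereas 3-hydroxypropyl gave the lower number in the same comparison. With the 2-hydroxyethyl chain in place, fluoro in place of hydrogen on an aromatic carbon gives a 1.4-fold higher number from compound 1 to compound 4 (0.15 log units; within the scatter), so this swap makes no readable difference here.

From the compounds shown here alone, whether a longer chain such as 4-hydroxybutyl would lower the number further, or whether an amine or a carboxylic acid at the chain end would serve as well as the hydroxy group, remains open. No measurement at hand explains the size of the chain-length step.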